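This account rests on a few compounds, and the source may have more. Where it says the series, first, only, none or still open, it means among the compounds named here.

Values in a functional assay on HSC-4 cells (Homo sapiens) for cytotoxicity, with a stated time of 24 h (on this read-out lower numbers stand for higher toxicity in this test and higher numbers for lower toxicity in this test), so far
Compound 1 `COc1ccc(/C=C2\CCC/C(=C\c3ccccc3[N+](=O)[O-])C2=O)cc1` gives 24000 nM
Compound 2 `O=C1/C(=C/c2ccc(F)cc2)CCC/C1=C\c1cccc([N+](=O)[O-])c1` gives 2500 nM
Compound 3 `O=C1/C(=C/c2ccccc2)CCC/C1=C\c1ccc([N+](=O)[O-])cc1` gives 9200 nM

Compound 3 (9200 nM) is the second highest of the three, with compound 1 the nearest on the higher side and compound 2 the furthest on the lower side. Both gaps lie beyond the scatter. The step to compound 4 `CN(C)c1ccc(/C=C2\CCC/C(=C\c3ccc([N+](=O)[O-])cc3)C2=O)cc1` puts dimethylamino in place of hydrogen on an aromatic carbon, para to a large group, so that phenyl becomes 4-(dimethylamino)phenyl (dimethylamino in place of hydrogen on an aromatic carbon) while the rest of compound 3 stays the same.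

Within the data shown here, no two measured compounds differ in one place only, so the data offer no direct guide to this change. Compound 1 (24000 nM) and compound 2 (2500 nM) both carry a substituent on the ring that changes here, yet they fall on opposite sides of compound 3, and their nitro groups are placed differently as well. In this assay no step beyond the scatter is therefore expected, with only a slight lean towards a higher number. The estimated step is small (a 1.2-fold higher number from compound 3 to compound 4 (0.08 log units; within the scatter)) and stays within that scatter. Compound 4 is estimated at 11000 nM with 3500 nM to 35000 nM as the expected range.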

Compound 4, half-maximal cytotoxic concentration: > 400000 nM
Compound 4: no number, only a limit; the forecaster's own chance of this, stated with the estimate: 8%; middle value at least 36-fold (1.56 log units) from the limit.
By their numbers in this assay, from the lowest: compound 2; then compound 3; then compound 1. At a limit, above all of these: compound 4.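

Turning phenyl into 4-(dimethylamino)phenyl gives an at least 43-fold higher number from compound 3 to compound 4 (1.63 log units; beyond the scatter), a large step towards lower toxicity in this assay. This is the only comparison among the compounds shown that rests on a change in one place, and it shows that this ring position, para to a large group, is far from indifferent to what it carries in this test. Compound 4 gives no number, only a limit, and it is the one compound shown that stands there: the limit of > 400000 nM in this assay, at which 1 of the 4 values shown sits.

From the compounds shown here alone, whether the step belongs to dimethylamino itself or would also appear with a plain amino group, a morpholine ring or a carboxylic acid on the same aromatic carbon remains open, as does how far the true value of compound 4 lies past its limit. Compound 1 and compound 2 also carry a substituent on this ring, but their nitro groups are placed differently from that of compound 3, so they cannot settle how other groups at this position behave.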